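Swapping a Trifluoromethoxyphenyl for a Fluorophenyl Group

A few compounds are considered here, and "the series" means these few. Any claim that something is new, unique, unknown or untested is made for them only; others in the source may bear on it.

Compound 3 `Cc1cc(=O)n(-c2ccccc2OC(F)(F)F)nc1C(=O)Nc1ccc(Oc2ncnc3sccc23)cc1` gives 14400 nM in a functional assay on HepG2 cells (Homo sapiens) for cytotoxicity, read by MTT assay, with a stated time of 72 h (on this read-out lower numbers stand for stronger inhibition and higher numbers for weaker inhibition), the highest of the three numbers recorded. Its nearest neighbour is compound 1 `Cc1cc(=O)n(-c2cccc(F)c2)nc1C(=O)Nc1ccc(Oc2ncnc3ccsc23)cc1`, which gives 10200 nM, within the scatter of compound 3, and the furthest is compound 2 `Cc1cc(=O)n(-c2ccc(Br)cc2F)nc1C(=O)Nc1ccc(Oc2ncnc3sccc23)cc1`, which gives 6300 nM. Going by the values given here, the only single-point step among the measured compounds is a 2.3-fold higher number from compound 2 to compound 3 (0.36 log units; beyond the scatter), a modest change beyond the scatter. Compound 4 `Cc1cc(=O)n(-c2cccc(F)c2)nc1C(=O)Nc1ccc(Oc2ncnc3sccc23)cc1` arises from compound 3 by 3-fluorophenyl in place of 2-(trifluoromethoxy)phenyl on an aromatic nitrogen. The step from compound 2 to compound 3 bears on this change, since it also exchanges the group on the same aromatic nitrogen, though with a different pair of groups. Compound 1 carries the same 3-fluorophenyl group as compound 4 on a core that differs from it in one place, and its value in this assay sits within the scatter of compound 3. From these two pointers a step of a 1.4-fold lower number from compound 3 to compound 4 (0.16 log units; within the scatter) is expected in this assay, no larger than the scatter. Compound 4 is therefore estimated at 10000 nM, within a range from 4000 nM to 25000 nM.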

Compound 4, half-maximal inhibitory concentration: 18500 nM
For compound 4 the middle estimate is 1.9-fold (0.27 log units) below the measured one, within the range that was stated.
By their numbers in this assay, from the lowest: compounds 2, 1, 3 and 4 (each within the scatter of the next, the first and the last beyond it).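

In this assay the exchange of 2-(trifluoromethoxy)phenyl for 3-fluorophenyl on the aromatic nitrogen gives a 1.3-fold higher number from compound 3 to compound 4 (0.11 log units; within the scatter) and so does not separate these two groups, despite their different sizes. Only the 4-bromo-2-fluorophenyl group stands apart at this position, with a 2.9-fold higher number from compound 2 to compound 4 (0.47 log units; beyond the scatter) alongside a 2.3-fold higher number from compound 2 to compound 3 (0.36 log units; beyond the scatter) while the change of the core with 3-fluorophenyl in place gives a 1.8-fold higher number from compound 1 to compound 4 (0.26 log units; within the scatter) and also stays small. No measurement at hand bears on why the 4-bromo-2-fluorophenyl group stands apart.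

From the compounds shown here alone, it remains open whether the lower number of compound 2 goes with its bromine or with the pairing of bromine and fluorine. How an amine or a carboxylic acid on this phenyl ring would read in this assay is also unknown.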